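From Bromo to Phenoxy in a Flat Series

The source may report more compounds than this note shows. Statements on the series, on what has been measured and on what is new or still open speak of the compounds shown alone.

Results in a functional assay on M21 cells (Homo sapiens) for antiproliferative activity, read by sulforhodamine B assay, with a stated time of 48 h (on this read-out higher numbers stand for weaker inhibition and lower numbers for stronger inhibition), so far
Compound 1 `Cc1cccc(NS(=O)(=O)c2ccc(N3CCNC3=O)cc2)c1` gives 69 nM
Compound 2 `CCc1cccc(NS(=O)(=O)c2ccc(N3CCNC3=O)cc2)c1` gives 82 nM
Compound 3 `O=C1NCCN1c1ccc(S(=O)(=O)Nc2cccc(Br)c2)cc1` gives 59 nM
Compound 4 `O=C1NCCN1c1ccc(S(=O)(=O)Nc2cccc(Oc3ccccc3)c2)cc1` has no result yet

The three measured compounds sit close together. Compound 3 cannot be separated from the other two, as both of its steps stay within the scatter (a 1.2-fold lower number from compound 1 to compound 3 (0.07 log units; within the scatter) and a 1.4-fold lower number from compound 2 to compound 3 (0.14 log units; within the scatter)). The same holds for the remaining step (a 1.2-fold higher number from compound 1 to compound 2 (0.07 log units; within the scatter)).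

The next change is larger: phenoxy in place of bromo on an aromatic carbon in the shared core. The three measured steps bear on it only weakly. Going by the values given here, they exchange methyl, ethyl and bromo, whereas phenoxy brings a whole extra ring, and no measured compound carries such a group. The flat results therefore say little about what a group of this size will do, and the data fix no direction. A cautious expectation is a modest loss from the level of compound 3 (59 nM), with real uncertainty on both sides. In this assay the expected change is a 2.2-fold higher number from compound 3 to compound 4 (0.34 log units; beyond the scatter) towards weaker inhibition. Compound 4 is estimated at 130 nM (expected range 35 nM to 500 nM).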

Compound 4, half-maximal inhibitory concentration: 83 nM
For compound 4 the middle estimate is 1.6-fold (0.19 log units) above the measured one; low and high end bracket the measured number.
By their numbers in this assay, from the lowest: compounds 3, 1, 2 and 4 (each within the scatter of the next).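

In this assay, replacing the single bromine with phenoxy brings in 7 heavy atoms and a whole six-membered aromatic ring, yet the result stays within the scatter, with a 1.4-fold higher number from compound 3 to compound 4 (0.15 log units; within the scatter). The comparisons with the smaller groups read the same way, with a 1.0-fold higher number from compound 2 to compound 4 (0.01 log units; within the scatter) and a 1.2-fold higher number from compound 1 to compound 4 (0.08 log units; within the scatter). This shows something that methyl, ethyl and bromo could not show on their own: this aromatic carbon, meta to a large group, can carry a much bigger group, one with an extra ring, without a change these numbers can separate, although nothing available here explains why.

The compounds shown leave open whether the same position would remain as undemanding with an amine or a carboxylic acid in place of phenoxy. Going by these compounds, it is also open whether adding a chloro or methoxy group to the new phenoxy ring would move the number beyond the scatter, which would show whether that ring can influence the result at all.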